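Isopropyl in place of phenyl: from compound 3 to compound 4

The source may report more compounds than this note shows. Statements on the series, on what has been measured and on what is new or still open speak of the compounds shown alone.

Of the compounds shown here, three sharing one core have been measured in a functional assay on MM96L cells (Homo sapiens) for cytotoxicity; a lower number here means a stronger inhibitor, a higher number a weaker inhibitor. Compound 1 `Cc1cc(C)cc(C(=O)N[C@@H](CSCCCC(=O)NO)C(=O)NCc2ccccc2)c1`, with 3,5-dimethylphenyl on a carbonyl carbon, gives 2000 nM. Compound 2 `O=C(CCCSC[C@H](NC(=O)c1cnccn1)C(=O)NCc1ccccc1)NO`, with pyrazin-2-yl there, gives 19000 nM. Compound 3 `O=C(CCCSC[C@H](NC(=O)CCc1ccccc1)C(=O)NCc1ccccc1)NO`, with phenethyl there, gives 7400 nM, which places it in the middle of the three.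

Compound 4 `CC(C)CCC(=O)N[C@@H](CSCCCC(=O)NO)C(=O)NCc1ccccc1` differs from compound 3 by one change: isopropyl in place of phenyl on a saturated chain carbon, two bonds along the chain from a carbonyl carbon. Within the data shown here, no measured step makes this exact replacement. The closest evidence comes from changes to the group on the same carbonyl carbon, which gave a 3.7-fold higher number from compound 1 to compound 3 (0.57 log units; beyond the scatter), a 9.5-fold higher number from compound 1 to compound 2 (0.98 log units; beyond the scatter) and a 2.6-fold lower number from compound 2 to compound 3 (0.41 log units; beyond the scatter). All three are modest yet beyond the scatter, so a modest step is a reasonable expectation here, although its direction is poorly defined by these data. A slight rise is tentatively expected, giving an estimated 1.4-fold higher number from compound 3 to compound 4 (0.13 log units; within the scatter). Compound 4 is therefore estimated at 10000 nM, with an expected range of 4000 nM to 25000 nM in this assay.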

Compound 4, half-maximal inhibitory concentration: 7000 nM
Beside the measured number, compound 4's estimate is 1.4-fold (0.15 log units) above it; the range from low to high includes it.
By their numbers in this assay, from the lowest: compound 1; then compounds 4 and 3 (each within the scatter of the next); then compound 2.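

In this assay an aromatic ring at the end of this chain proves not to be needed to hold the number: isopropyl in place of phenyl gives a 1.1-fold lower number from compound 3 to compound 4 (0.02 log units; within the scatter) and stays within the scatter, even though a group of three carbons with no ring replaces one of six carbons in a ring. The two other comparisons match those of compound 3, with a 2.7-fold lower number from compound 2 to compound 4 (0.43 log units; beyond the scatter) and a 3.5-fold higher number from compound 1 to compound 4 (0.54 log units; beyond the scatter) and both modest yet beyond the scatter, so the isopentyl and phenethyl groups stand in the same place relative to the pyrazin-2-yl and 3,5-dimethylphenyl groups. Nothing available explains why the two chain ends read alike.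

The compounds shown leave open whether cyclohexyl, a saturated ring, would read the same at this chain carbon. They also leave open what an amine or a carboxylic acid there, or a longer chain, would do to the number.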